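This account rests on a few compounds, and the source may have more. Where it says the series, first, only, none or still open, it means among the compounds named here.

For the measured compounds named here, only two compounds have numbers so far in a functional assay on T98G cells (Homo sapiens) for inhibition, read by colorimetric assay and MTT assay, with a stated time of 72 h; on this read-out higher numbers stand for weaker inhibition and lower numbers for stronger inhibition. There, compound 1 `Cn1c2cnc1OCCCCCCCCCCCOc1ccccc1-2` gives 56000 nM, and compound 2 `C=CCCCCOc1ccc(C)cc1-c1cnc(OCCC=C)n1C` gives 94000 nM. These two values lie within the usual scatter of repeated measurements, so compound 2 stands level with compound 1 on the data available. Going by the values given here, the two structures differ in more than one place, so this pair offers no measured example of what a single small change does.

The next compound, compound 3 `C=CCCCCOc1ccc(F)cc1-c1cnc(OCCC=C)n1C`, departs from compound 2 at a single spot: fluoro in place of methyl on an aromatic carbon. This is fluoro in place of methyl on an aromatic carbon, para to a (hex-5-en-1-yl)oxy group, and the rest of the molecule stays the same. Among the compounds with values here, with only one small group exchanged and no measured step to suggest otherwise, no shift beyond the scatter is expected in this assay. The estimated 1.2-fold lower number from compound 2 to compound 3 (0.07 log units; within the scatter) therefore stays small, with no firm direction. For compound 3, the expected value is 80000 nM, with an estimated range from 40000 nM to 160000 nM.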

Compound 3, half-maximal inhibitory concentration: 87000 nM
For compound 3 the middle estimate is 1.1-fold (0.04 log units) below the measured one; low and high end bracket the measured number.
By their numbers in this assay, from the lowest: compounds 1, 3 and 2 (each within the scatter of the next).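

In this assay the series now has its first measured step at a single place: the exchange gives a 1.1-fold lower number from compound 2 to compound 3 (0.03 log units; within the scatter) and so leaves the two compounds level. At this aromatic carbon, para to a (hex-5-en-1-yl)oxy group, the read-out therefore does not tell methyl and fluoro apart, something the earlier pair could not show, since compound 1 and compound 2 differ in more than one place. No other measurement bears on why these two groups stand level, so the result remains a plain observation.

As far as these compounds go, what a group other than these two would do at this same carbon stays open, whether a methoxy group, an amine, a carboxylic acid or a longer chain, and any of these might or might not move the number beyond the usual scatter. Also open, from the compounds shown here alone, is whether fluoro in place of methyl would read the same on a different background, such as the closed-chain structure of compound 1, because a single step on one molecule says nothing yet about other molecules.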